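The compounds below may be only part of what the source reports. "The series", "measured", "known", "first", "only" and "open" are said of these compounds alone.

Compound 1, `CCOC(=O)CC[C@H](NC(=O)c1ccc(CNc2ccc3nc(N)nc(N)c3c2)cc1)C(=O)OCC`, is the most potent of three compounds measured in an assay for inhibition of Dihydrofolate reductase (Homo sapiens) (a higher number here means a more potent compound, by a factor of ten per unit of this negative logarithm, a lower number a less potent compound), where compound 1 gives 7.54. Two much smaller compounds share its core. Compound 3, `Cc1ccc2nc(N)nc(N)c2c1`, gives 5.66 in this assay, and compound 2, `Cc1ccc2nc(N)nc(O)c2c1`, gives 4.44. Compound 2 differs from compound 3 in one place: hydroxy in place of amino on an aromatic carbon. That single change made a step of a number 1.22 log units lower from compound 3 to compound 2 (beyond the scatter). How the core of compound 1 differs from the core of compound 3 is not broken down here.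

Compound 4, `CCOC(=O)CC[C@H](NC(=O)c1ccc(CNc2ccc3nc(N)nc(O)c3c2)cc1)C(=O)OCC`, is not yet measured. It differs from compound 1 in one place: hydroxy in place of amino on an aromatic carbon. Going by the values given here, this is the same change as the one from compound 3 to compound 2, and it sits at exactly the same kind of place. Since the only example seen cost compound 3 a large amount, shown by a number 1.22 log units lower from compound 3 to compound 2 (beyond the scatter), a loss of similar size is expected for compound 4, a number 1.24 log units lower from compound 1 to compound 4 (beyond the scatter). Whether the much larger compound 1 responds in the same way cannot be told from two compounds alone, so the range is kept wide. Compound 4 is therefore estimated at 6.3, between 5.6 and 7.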

Compound 4, logarithm of the reciprocal of the active concentration, log(1/C): 6.24
The estimate for compound 4 lay 0.06 log units above the measured number; the measured number falls inside the stated range.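

In this assay, hydroxy in place of amino on an aromatic carbon brought a large loss once more, with a number 1.30 log units lower from compound 1 to compound 4 (beyond the scatter). Set beside the earlier case, the loss on the much larger compound 1 matches the loss on the small core, so the change carried over from one core to the other with no measurable difference in size: the same change on two cores in this assay, a number 1.22 log units lower (beyond the scatter) from compound 3 to compound 2 and a number 1.30 log units lower (beyond the scatter) from compound 1 to compound 4, 0.08 log units apart, within the scatter of two such steps This holds for only two pairs of compounds, so it does not show that the same loss would appear on every core in this series, and it says nothing about why the change costs this much.

The compounds shown leave open how other groups would fare at the same place on the ring, such as a methoxy group, a methylamino group or a plain hydrogen. They also leave open whether the step keeps its size when a carboxylic acid stands in place of the ethyl esters of compound 1.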